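The source may hold more compounds than are shown below. What is called first, only, known or untested is meant among the compounds shown, and "the series" means these compounds.

Compound 1 `CCCS(=O)(=O)Nc1ccc(F)c(C(=O)c2n[nH]c3ncc(-c4cccc(O)c4)cc23)c1F` gives 2.2% in an assay for binding affinity to dual specificity mitogen-activated protein kinase kinase 4 (Homo sapiens), read by KINOMEscan, tested at 100 nM; on this read-out lower numbers stand for a stronger effect and higher numbers for a weaker effect at the one concentration tested.
Compound 2 `CCCS(=O)(=O)Nc1ccc(F)c(C(=O)c2n[nH]c3ncc(-c4ccc(S(N)(=O)=O)cc4)cc23)c1F` gives 0.25% in this assay.

Within the data shown here, compound 2 holds the lower of the two numbers, yet its only neighbour is near: a number 2 percentage points lower from compound 1 to compound 2 (within the scatter). Compound 3 `CCCS(=O)(=O)Nc1ccc(F)c(C(=O)c2n[nH]c3ncc(-c4ccc(-c5nnn[nH]5)cc4)cc23)c1F` differs from compound 2 by 1H-tetrazol-5-yl in place of sulfamoyl on an aromatic carbon. Among the measured compounds shown here, the one measured step bears on this only loosely, as it changed a group on the same aromatic carbon and stayed within the scatter; nothing measured exchanges sulfamoyl itself. On that basis no step beyond the scatter is expected: a number 1.3 percentage points higher from compound 2 to compound 3 (within the scatter). Compound 3 is estimated at 1.5%, with a range from 0.1% to 15%.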

Compound 3, a percentage reported as activity, at one concentration (the size of the read-out at that concentration, not a potency): 0.15%
Compound 3: the middle estimate sits 1.4 percentage points above what was measured; measured number inside the range.
By their numbers in this assay, from the lowest: compounds 3, 2 and 1 (each within the scatter of the next).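

With a number 0.1 percentage points lower from compound 2 to compound 3 (within the scatter) in this assay, 1H-tetrazol-5-yl stands in for sulfamoyl on this aromatic carbon without a step beyond the scatter, so the place tolerates a five-membered aromatic ring as well as an open sulfamoyl group. With a number 2.1 percentage points lower from compound 1 to compound 3 (within the scatter) as well, all three aryl groups shown remain within the scatter of one another. Nothing at hand explains this result.

The compounds shown leave open whether a carboxylic acid or an amine on the same aromatic carbon would read alike. They also leave open whether a longer chain there would do so.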